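This account rests on a few compounds, and the source may have more. Where it says the series, first, only, none or still open, it means among the compounds named here.

Among the measured compounds shown here, compound 2 `O=C(NO)C(F)(F)C(F)(F)C(F)(F)C(F)(F)C(F)(F)C(F)(F)C(=O)Nc1ccc(I)cc1` gives 4100 nM in an assay on isolated protein for inhibition of histone deacetylase 7 (Homo sapiens), read by fluorescence (a lower number here means tighter binding, a higher number weaker binding), the lower of the two numbers known; compound 1 `CC(=O)Nc1ccc(NC(=O)C(F)(F)C(F)(F)C(F)(F)C(F)(F)C(F)(F)C(F)(F)C(=O)NO)cc1` gives 13000 nM in this assay. For the measured compounds named here, the one measured step, a 3.2-fold lower number from compound 1 to compound 2 (0.50 log units; beyond the scatter), is a change at the same aromatic carbon, yet it swaps a small group for another small group. Compound 3 `O=C(NO)C(F)(F)C(F)(F)C(F)(F)C(F)(F)C(F)(F)C(F)(F)C(=O)Nc1ccc(-c2cn(-c3ccccc3)nn2)cc1` carries 1-phenyl-1H-1,2,3-triazol-4-yl in place of iodo on an aromatic carbon. Going by the values given here, no measured step bears directly on an extension of this size at that position, so the step from compound 2 to compound 3 in this assay can only be expected to be modest, with a slight lean toward a lower number given that the iodo-bearing compound 2 already sits below compound 1; a step of a 1.6-fold lower number from compound 2 to compound 3 (0.21 log units; within the scatter) is expected. Compound 3 is therefore estimated at 2500 nM in this assay, within 600 nM to 10000 nM.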

Compound 3, dissociation constant: 30000 nM
Beside the measured number, compound 3's estimate is 12-fold (1.08 log units) below it, outside the stated range (above it).
By their numbers in this assay, from the lowest: compound 2; then compound 1; then compound 3.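

In this assay the group 1-phenyl-1H-1,2,3-triazol-4-yl on this aromatic carbon brings a 7.3-fold higher number from compound 2 to compound 3 (0.86 log units; beyond the scatter) and a 2.3-fold higher number from compound 1 to compound 3 (0.36 log units; beyond the scatter) when it replaces iodo and acetamido in turn. The earlier pair covered only iodo and acetamido; this change shows that a group with two aromatic rings does not carry the lowering seen with iodo any further, and it leaves compound 3 with the highest number of the three. Nothing at hand accounts for this rise.

Whether the rise belongs to the triazole ring, the terminal phenyl or the overall length of the group stays open, as these change together in the compounds shown. Going by these compounds, how an amine, a carboxylic acid or a triazole bearing methyl instead of phenyl would read at this carbon in this assay also stays open.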